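This account rests on a few compounds, and the source may have more. Where it says the series, first, only, none or still open, it means among the compounds named here.

Series notes. Compound 1 `COc1ccc(/C=C/C2CC=CC(=O)O2)cc1` and compound 2 `COc1ccc(/C=C/C2CC=CC(=O)O2)cc1OC` share one core; compound 3 `COc1ccc(/C=C/C2CC=CC(=O)N2)cc1OC` and compound 4 `COc1cc(OC)c(OC)cc1/C=C/C1CC=CC(=O)N1` share another, and the difference between the two cores is not broken down here. In an ADME assay on HaCaT cells (Homo sapiens) for inhibition, read by sulforhodamine B assay, with a stated time of 48 h (a lower number here means a stronger inhibitor of growth, a higher number a weaker inhibitor of growth), compound 1 gives 58.8 uM. In this assay compound 2 gives 63 uM. The change from compound 1 to compound 2 is methoxy in place of hydrogen on an aromatic carbon, and it made a 1.1-fold higher number from compound 1 to compound 2 (0.03 log units; within the scatter). In this assay compound 3 gives only a limit, > 964 uM, and that reading is a limit of the assay (the limit of > 964 uM in this assay, at which 1 of the 3 values shown sits). Compound 4 has not been measured in this assay. The change from compound 3 to compound 4 is methoxy in place of hydrogen on an aromatic carbon. Within the data shown here, it is the same kind of change as the one from compound 1 to compound 2, though the surroundings differ: in compound 2 the methoxy enters ortho to a methoxy group and meta to a group of 9 heavy atoms, whereas in compound 4 it enters ortho to a group of 9 heavy atoms, meta to a methoxy group and para to a methoxy group. Among the measured compounds shown here, the one measured step of this kind, a 1.1-fold higher number from compound 1 to compound 2 (0.03 log units; within the scatter), sits within the scatter, so a step of about the same size is expected, a step that the limit leaves unreadable from compound 3 to compound 4. Because compound 3 already sits at the limit (the limit of > 964 uM in this assay, at which 1 of the 3 values shown sits), compound 4 is expected to give an estimated 1500 uM, and this assay is expected most likely to report only a limit again.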

Compound 4, concentration for growth inhibition (reported as GI): > 864 uM
Compound 4 gave a limit, no number; the forecaster's own chance of this, stated with the estimate: 85%; the middle value lies beyond the limit too.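

No step can be read between compound 3 and compound 4, since each gives only a limit and no number. The limit for compound 3 is: the limit of > 964 uM in this assay, at which 1 of the 4 values shown sits. The limit for compound 4 is: the limit of > 864 uM in this assay, at which 1 of the 4 values shown sits. The compounds shown leave open whether methoxy in place of hydrogen on an aromatic carbon changes the reading at all on the core of compound 3 in this assay.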